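Pentafluorosulfanyl anilides with trifluoromethylphenyl thioethers

The compounds below may be only part of what the source reports. "The series", "measured", "known", "first", "only" and "open" are said of these compounds alone.

Measured so far in a functional assay on LNCaP cells (Homo sapiens) for antiproliferative activity, read by propidium iodide staining, with a stated time of 96 h; on this read-out lower numbers stand for stronger inhibition and higher numbers for weaker inhibition:
compound 1 `CC(O)(CSc1cccc(C(F)(F)F)c1)C(=O)Nc1ccc(S(F)(F)(F)(F)F)cc1` gives 18300 nM
compound 2 `CC(O)(CSc1ccccc1C(F)(F)F)C(=O)Nc1ccc(S(F)(F)(F)(F)F)cc1` gives 12300 nM
compound 3 `CC(O)(CSc1cccc(C(F)(F)F)c1)C(=O)Nc1cccc(S(F)(F)(F)(F)F)c1` gives 12700 nM

All three numbers lie within the scatter of one another in this assay, so no order among them can be read. Within the data shown here, the one single-point change measured so far is 2-(trifluoromethyl)phenyl in place of 3-(trifluoromethyl)phenyl on a sulfur, which gave a 1.5-fold lower number from compound 1 to compound 2 (0.17 log units; within the scatter). Compound 3 and compound 1 differ in the other half of the molecule; the difference between the two cores is not broken down here.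

Compound 4 `CC(O)(CSc1ccccc1C(F)(F)F)C(=O)Nc1cccc(S(F)(F)(F)(F)F)c1` has not been measured. It relates to compound 3 by 2-(trifluoromethyl)phenyl in place of 3-(trifluoromethyl)phenyl on a sulfur, the same change as that from compound 1 to compound 2, made at the same place. Given that compound 1 to compound 2 gave a 1.5-fold lower number from compound 1 to compound 2 (0.17 log units; within the scatter), a step of similar size, within the scatter, is expected here as well, so the expected step is a 1.3-fold lower number from compound 3 to compound 4 (0.13 log units; within the scatter). On that basis compound 4 is estimated to give 9500 nM in this assay, with an expected range from 4500 nM to 20000 nM.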

Compound 4, half-maximal inhibitory concentration: 12300 nM
Beside the measured number, compound 4's estimate is 1.3-fold (0.11 log units) below it; the measured number falls inside the stated range.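

In this assay the swap of 2-(trifluoromethyl)phenyl for 3-(trifluoromethyl)phenyl on a sulfur gives a 1.0-fold lower number from compound 3 to compound 4 (0.01 log units; within the scatter) on this second core as well. Set side by side, the two steps do not differ, so the change can be carried from one core to the other without a detectable difference in its size: the same change on two cores in this assay, a 1.5-fold lower number (0.17 log units; within the scatter) from compound 1 to compound 2 and a 1.0-fold lower number (0.01 log units; within the scatter) from compound 3 to compound 4, 1.4-fold (0.16 log units) apart, within the scatter of two such steps
Neither step is beyond the scatter, so what carries across is only the absence of a readable effect, and the pair does not show that this change moves the number on either core, nor how it would behave on any core other than these two.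

From the compounds shown here alone, all four compounds keep a trifluoromethyl group on the phenyl ring attached to sulfur, so it remains open how the number responds to a nitrile or a chlorine in its place. Also open, going by these compounds, is whether a sulfone in place of the thioether sulfur, or a nitrile in place of the pentafluorosulfanyl group on the anilide, would give a step beyond the scatter in this assay at all.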